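Morpholin-4-yl to 4-Methylpiperazin-1-yl: What Compound 4 Might Show

This account rests on a few compounds, and the source may have more. Where it says the series, first, only, none or still open, it means among the compounds named here.

Of the compounds shown here, three have been measured so far, all sharing a related core. Compound 1 `COC(=O)CC1c2ccccc2N=C(N2CCOCC2)N1C1CCCCC1` gives in a functional assay on cells (Oocyte) for inhibition of Voltage-dependent T-type calcium channel subunit alpha-1H (Homo sapiens), tested at 100 uM (on this read-out higher numbers stand for more inhibition at the one concentration tested (going by the name of the read-out) and lower numbers for less inhibition), a value of 12.2%. Compound 2 `COC(=O)CC1c2ccccc2N=C(N2CCN(C)CC2)N1C1CCCCC1` differs from it by a single change, (4-methylpiperazin-1-yl in place of morpholin-4-yl on a carbon with a double bond to nitrogen), and in this assay compound 2 gives 3%. The step between these two is a number 9.2 percentage points lower from compound 1 to compound 2 (within the scatter).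

Compound 3 `O=C(CC1c2ccccc2N=C(N2CCOCC2)N1c1ccccc1)OCc1ccccc1` carries a different core; how the core of compound 3 differs from that of compound 1 is not broken down here. In this assay compound 3 gives 20.9%. Set against compound 1, the numbers of compound 3 and compound 1 lie within the usual scatter of each other, while compound 3 and compound 2 are separated by more than that scatter.

Compound 4 `CN1CCN(C2=Nc3ccccc3C(CC(=O)OCc3ccccc3)N2c2ccccc2)CC1` has not yet been measured. It arises from compound 3 by 4-methylpiperazin-1-yl in place of morpholin-4-yl on a carbon with a double bond to nitrogen. Going by the values given here, this is the same kind of change as the one from compound 1 to compound 2, though the surroundings of the place are not identical: in compound 3 the carbon with a double bond to nitrogen sits next to the ring atom that bears a phenyl group and two ring bonds from the ring atom that bears a (benzyloxycarbonyl)methyl group, whereas in compound 1 those ring atoms bear a cyclohexyl group and a (methoxycarbonyl)methyl group.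

Among the compounds with values here, the expectation for compound 4 rests on the one measured instance of this change, namely the step of a number 9.2 percentage points lower from compound 1 to compound 2 (within the scatter), and so a step of a number 8.9 percentage points lower from compound 3 to compound 4 (within the scatter) is expected from compound 3 to compound 4. On that basis compound 4 is expected to give in this assay about 12%, with the range estimated to run from 2% to 25%.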

Compound 4, a percentage reported as inhibition, at one concentration (the size of the read-out at that concentration, not a potency): 32.7%
Compound 4: the middle estimate sits 20.7 percentage points below what was measured; measured number outside the range, above it.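

In this assay, placing 4-methylpiperazin-1-yl where morpholin-4-yl stood on the core of compound 3 gave a result that could not have been read off the earlier pair, a number 11.8 percentage points higher from compound 3 to compound 4 (beyond the scatter). Set beside the earlier step, the same change does not transfer as a fixed increment between these two cores: the same change on two cores in this assay, a number 9.2 percentage points lower (within the scatter) from compound 1 to compound 2 and a number 11.8 percentage points higher (beyond the scatter) from compound 3 to compound 4, 21 percentage points apart, beyond the scatter of two such steps This shows that, in this series, the size of the step cannot simply be carried from one core to the other, but it does not show which difference between the cores matters, since phenyl and (benzyloxycarbonyl)methyl on one core replace cyclohexyl and (methoxycarbonyl)methyl on the other, and two pairs at a single concentration establish no general rule.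

The compounds shown never separate those two differences, so it remains open whether the step follows the phenyl group, the (benzyloxycarbonyl)methyl group or the two together. Also open, on these data alone, is how a piperidin-1-yl group or an open-chain dimethylamino group at the same place, or a free carboxylic acid in place of the ester, would read in this assay on either core.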